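The source may hold more compounds than are shown below. What is called first, only, known or untested is meant among the compounds shown, and "the series" means these compounds.

Measured compounds:
compound 1 `Clc1ccc(-c2cc(-c3ccccc3)c3cc(Br)ccc3n2)cc1` — 269000 nM
compound 2 `COc1cc(-c2cc(-c3ccccc3)c3cc(Br)ccc3n2)cc(OC)c1OC` — "not determined" (no result reported)

Of the compounds shown here, two share one core and have been tested in a functional assay on Hep2C cells (Homo sapiens) for antiproliferative activity, read by MTT assay, with a stated time of 24 h; on this read-out higher numbers stand for weaker inhibition and lower numbers for stronger inhibition. Compound 1, whose structure is `Clc1ccc(-c2cc(-c3ccccc3)c3cc(Br)ccc3n2)cc1`, gives 269000 nM in this assay, a concentration so high that it counts as very weak inhibition. Compound 2, with the structure `COc1cc(-c2cc(-c3ccccc3)c3cc(Br)ccc3n2)cc(OC)c1OC`, carries three methoxy groups on the same outer ring; in this assay compound 2 is recorded as "not determined" (no result reported), so no number exists for it. Among the compounds with values here, compound 1 therefore stands alone as the only compound with a number, and nothing can be said about its rank.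

Compound 3, with the structure `Oc1ccc(-c2cc(-c3ccccc3)c3cc(Br)ccc3n2)cc1`, has not yet been measured in this assay. It differs from compound 1 in one place: hydroxy in place of chloro on an aromatic carbon. Within the data shown here, no step between measured compounds is available to guide what this change does, so no direction beyond the scatter can be claimed for the step from compound 1 to compound 3. The expected result for compound 3 rests on compound 1 alone, whose 269000 nM already lies at the weak end. For compound 3 the estimated value is therefore 200000 nM, with a range from 50000 nM to 800000 nM, which means an expected step of a 1.3-fold lower number from compound 1 to compound 3 (0.13 log units; within the scatter).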

Compound 3, half-maximal inhibitory concentration: 105000 nM
Compound 3: the middle estimate sits 1.9-fold (0.28 log units) above what was measured; measured number inside the range.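

Within the data shown here, until now this position had no step to read, and the first one shows that the group para to a large group on the outer ring does affect the result. In this assay, hydroxy in place of chloro gives a 2.6-fold lower number from compound 1 to compound 3 (0.41 log units; beyond the scatter), a modest change but a real one, since it lies beyond the usual scatter of repeated measurements. Even so, compound 3 stays at 105000 nM, a very high concentration, so this swap improves the number without turning a weak inhibitor into a strong one, and no measurement at hand explains the shift.

This is a single step at a single position, so it gives no trend: chloro has no hydrogen-bond donor or acceptor and hydroxy has one of each, but two compounds cannot show whether that difference is what counts. From the compounds shown here alone, it also remains open whether an amine or a carboxylic acid at this same place would lower the number further or raise it again, and whether the swap from chloro to hydroxy would give a step of similar size elsewhere on the shared core.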